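Isoquinolinyl ether isomers in the Jurkat series

The compounds below may be only part of what the source reports. "The series", "measured", "known", "first", "only" and "open" are said of these compounds alone.

Compound 1: `CC(C)[C@H](NC(=O)COc1cccc2ccccc12)C(=O)N[C@@H](CC(=O)O)C(=O)COc1ccc2ccccc2n1`; > 200000 nM
Compound 2: `CC(C)[C@H](NC(=O)COc1cccc2ccccc12)C(=O)N[C@@H](CC(=O)O)C(=O)COc1cc2ccccc2cn1`; > 200000 nM
Compound 3: `CC(C)[C@H](NC(=O)COc1cccc2ccccc12)C(=O)N[C@@H](CC(=O)O)C(=O)COc1cncc2ccccc12`; not yet measured

In a functional assay on Jurkat cells (Homo sapiens) for inhibition (a lower number here means a stronger inhibitor, a higher number a weaker inhibitor), compound 1 gives only a limit, > 200000 nM. In this assay compound 2 likewise gives only a limit, > 200000 nM. The step that the two limits leave unreadable from compound 1 to compound 2 therefore cannot be read, and the limit of > 200000 nM in this assay, at which 2 of the 2 values shown sit, is all the two values share. Compound 2 thus stands at the limit of this assay, with no number of its own.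

Compound 3 differs from compound 2 by isoquinolin-4-yl in place of isoquinolin-3-yl on an oxygen on a saturated carbon. For the measured compounds named here, no measured step bears directly on this change, and the one step that exists, a step that the two limits leave unreadable from compound 1 to compound 2, gives no size. With both neighbours at the limit, compound 3 is expected to remain there as well. The expected step of a number no higher from compound 2 to compound 3 (the limit leaves the size open) is none beyond the scatter. The estimate for compound 3 in this assay is 200000 nM, within 100000 nM to 400000 nM.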

Compound 3, half-maximal inhibitory concentration: 166000 nM
Estimate against measurement, compound 3: 1.2-fold (0.08 log units) above; measured number inside the range.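

In this assay, for the compounds shown here, compound 3, with isoquinolin-4-yl on the oxygen, gives the first actual number at this position, where the earlier compounds gave only limits. Its comparisons are open-ended: an at least 1.2-fold lower number from compound 2 to compound 3 (0.08 log units; that floor lies within the scatter), and an at least 1.2-fold lower number from compound 1 to compound 3 (0.08 log units; that floor lies within the scatter). These floors establish no order among the three compounds, and the other two values remain limits: the limit of > 200000 nM in this assay, at which 2 of the 3 values shown sit.

As far as these compounds go, the true size of the change from isoquinolin-3-yl or quinolin-2-yl to isoquinolin-4-yl remains open, since compound 1 and compound 2 have no numbers of their own. Also open, from the compounds shown here alone, is whether an amine or a methoxy group on the isoquinolin-4-yl group, or a longer chain between it and the oxygen, would move the number in this assay clearly beyond the scatter.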